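A few compounds are considered here, and "the series" means these few. Any claim that something is new, unique, unknown or untested is made for them only; others in the source may bear on it.

Compound 1 `O[C@@H]1Cc2ccccc2N[C@H](c2ccccc2Cl)C1` is the starting point. In an ADME assay on THP-1 cells (Homo sapiens) for cytotoxicity, read by MTT assay, with a stated time of 72 h (on this read-out higher numbers stand for lower toxicity in this test and lower numbers for higher toxicity in this test), compound 1 gives > 300000 nM, and this is a limit of the assay rather than a measured number; the entry at the limit of > 300000 nM in this assay, at which 1 of the 2 values shown sits, marks it as such. Compound 2 `Cc1ccc2c(c1)C[C@@H](O)C[C@@H](c1ccccc1Cl)N2` carries a methyl in place of hydrogen on an aromatic carbon of the shared core, and in this assay compound 2 gives 85200 nM. That single change produced an at least 3.5-fold lower number from compound 1 to compound 2 (0.54 log units; beyond the scatter), a move toward higher toxicity in this test. Compound 3 `O[C@@H]1Cc2ccccc2N[C@H](c2c(Cl)cccc2Cl)C1` has not been measured. It differs from compound 1 by chloro in place of hydrogen on an aromatic carbon. Among the measured compounds shown here, only one measured step bears on it, the one from compound 1 to compound 2, which likewise placed a small group on an aromatic ring, though a different ring and a different group. On that slender basis a move in the same direction, toward a lower number, is expected, with the expected step being an at least 2.5-fold lower number from compound 1 to compound 3 (0.39 log units; beyond the scatter) in this assay. The estimate for compound 3 in this assay is 120000 nM, with a range from 30000 nM to 300000 nM.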

Compound 3, half-maximal cytotoxic concentration: > 300000 nM
Compound 3: no number, only a limit; the forecaster's own chance of this, stated with the estimate: 35%; at least 2.5-fold (0.39 log units) between middle value and limit.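

In this assay compound 3 gives > 300000 nM, which is a limit of the assay and not a number. Compound 1 also stands at a limit, so no step from compound 1 to compound 3 can be read: the limit of > 300000 nM in this assay, at which 2 of the 3 values shown sit.

The compounds shown leave open whether chloro in place of hydrogen changes the number at all, and in which direction.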